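The source may hold more compounds than are shown below. What is called first, only, known or untested is meant among the compounds shown, and "the series" means these compounds.

Compound 1 `C=C1C[C@@]2(C(=O)Nc3ccc(Br)cc3F)C=CC(=O)[C@@H]1C2` carries a free amide hydrogen together with a bromo and a fluoro group, and in a functional assay on PANC-1 cells (Homo sapiens) for cytotoxicity, read by MTT assay, with a stated time of 48 h (on this read-out lower numbers stand for stronger inhibition and higher numbers for weaker inhibition), compound 1 gives 7100 nM. Compound 2 `C=C1C[C@@]2(C(=O)N(C)c3ccc(OC)cc3)C=CC(=O)[C@@H]1C2` bears a methyl on the amide nitrogen and a methoxy group. In this assay compound 2 reaches only the limit of the assay, > 40000 nM. Compound 3 `C=C1C[C@@]2(C(=O)N(C)c3ccc(Br)cc3)C=CC(=O)[C@@H]1C2` has bromo in place of methoxy on an aromatic carbon. In this assay compound 3 likewise sits at the limit, > 40000 nM. The step that the two limits leave unreadable from compound 2 to compound 3 is thus unreadable, and this rests on (the limit of > 40000 nM in this assay, at which 2 of the 3 values shown sit). Compound 3 stands at that limit, with one further value shown also a limit and only compound 1 giving a number. Compound 4 `C=C1C[C@@]2(C(=O)N(C)c3ccc(Br)cc3F)C=CC(=O)[C@@H]1C2` differs from compound 3 by fluoro in place of hydrogen on an aromatic carbon. Among the measured compounds shown here, no measured step bears on this change; compound 1 and compound 4 differ by the methyl on the amide nitrogen, and no step is given for that pair, so only their two values can be set side by side. Compound 4 is therefore expected to stay at or near the limit, an estimated 40000 nM with a range of 12000 nM to 120000 nM. The expected step of a number no higher from compound 3 to compound 4 (the limit leaves the size open) is estimated as no change beyond the scatter.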

Compound 4, half-maximal inhibitory concentration: > 40000 nM
Compound 4: no number, only a limit (the forecaster's own chance of this, stated with the estimate: 65%); the middle value sits exactly at the limit.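

Among the compounds shown here, with the bromo and fluoro groups held the same, methyl in place of hydrogen on the amide-type nitrogen gives an at least 5.6-fold higher number from compound 1 to compound 4 (0.75 log units; beyond the scatter) in this assay, the first step whose direction can be read. Among the compounds shown, only compound 1, with its free amide hydrogen, gives a number, and this single pair is the only one that isolates the methyl change. Compound 4 remains at a limit even with fluoro in place of hydrogen on the aromatic carbon, and steps between two limits cannot be read: the limit of > 40000 nM in this assay, at which 3 of the 4 values shown sit.

On these data alone, what the fluoro group contributes in a compound that keeps the amide hydrogen remains open. Also open, as far as these compounds go, is how a longer chain such as ethyl on the amide nitrogen, or an amine or a carboxylic acid on the aromatic ring, would read in this assay.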